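The compounds below may be only part of what the source reports. "The series", "measured", "known", "first", "only" and "open" are said of these compounds alone.

Measured so far:
- compound 1 `Nc1ccccc1NC(=O)/C=C/c1ccc(CSc2cccc(F)c2)cc1`: 3.22%
- compound 2 `CC(C)(C)c1ccc(SCc2ccc(C(=O)Nc3ccccc3N)cc2)cc1`: 60.5%

In a functional assay on HCT-116 cells (Homo sapiens) for inhibition, read by CCK-8 assay, with a stated time of 72 h, tested at 8 uM (on this read-out lower numbers stand for less inhibition of growth and higher numbers for more inhibition of growth at the one concentration tested), compound 1 gives 3.22%, the lower of the two numbers and beyond the scatter from compound 2. Compound 3 `CC(C)(C)c1ccc(SCc2ccc(/C=C/C(=O)Nc3ccccc3N)cc2)cc1` differs from compound 1 by 4-(tert-butyl)phenyl in place of 3-fluorophenyl on a sulfur. Among the compounds with values here, no measured pair differs in one place only, so the expectation is loosely based. Compound 2, which also carries 4-(tert-butyl)phenyl on a sulfur, gives 60.5%. An upward move beyond the scatter is expected, estimated as a number 31.8 percentage points higher from compound 1 to compound 3 (beyond the scatter). For compound 3 the expected value is 35%, with an estimated range of 10% to 65%.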

Compound 3, percent growth inhibition at one concentration: 39%
Compound 3: middle estimate off by 4 percentage points, on the low side, and the stated range covers the measured number.
By their numbers in this assay, from the lowest: compound 1; then compound 3; then compound 2.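

Within this assay the change to 4-(tert-butyl)phenyl in place of 3-fluorophenyl on a sulfur reads as a number 35.8 percentage points higher from compound 1 to compound 3 (beyond the scatter) and gives the series its first single-place step. The group on the sulfur is thus a position where one change alone moves growth inhibition substantially on the core of compound 1. Nothing available accounts for this step.

Going by these compounds, whether the size of the step comes from adding the tert-butyl group or from losing the fluorine stays open. An unsubstituted phenyl or a 4-methoxyphenyl on the sulfur would bear on that question.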